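The source may report more compounds than this note shows. Statements on the series, on what has been measured and on what is new or still open speak of the compounds shown alone.

Measured in a functional assay on NCI-H522 cells (Homo sapiens) for inhibition, read by colorimetric assay and sulforhodamine B assay, with a stated time of 48 h; a higher number here means a weaker inhibitor of growth, a lower number a stronger inhibitor of growth:
- compound 1 `CCCCCCCCCCCC[C@@H](O)[C@H]1CC[C@H]([C@H](O)CCCCCCCCCCNC(=O)c2cccs2)O1`: 1100 nM
- compound 2 `CCCCCCCCCCCC[C@@H](O)[C@H]1CC[C@H]([C@H](O)CCCCCCCCCCNC(=O)c2ccco2)O1`: 18200 nM

Compound 2 has the higher of the two numbers, so it is the weaker inhibitor of growth. Among the measured compounds shown here, the only measured step, a 17-fold higher number from compound 1 to compound 2 (1.22 log units; beyond the scatter), came from furan-2-yl in place of thiophen-2-yl on a carbonyl carbon. Compound 3 `CCCCCCCCCCCC[C@@H](O)[C@H]1CC[C@H]([C@H](O)CCCCCCCCCCNC(=O)c2ccoc2)O1` has the same atoms as compound 2, joined differently: furan-3-yl in place of furan-2-yl on a carbonyl carbon. For the measured compounds named here, no measured step covers this exact swap, so the evidence is indirect. Still, a 17-fold higher number from compound 1 to compound 2 (1.22 log units; beyond the scatter) shows that the group on this carbonyl carbon can matter greatly in this assay. Compound 2 also sits at the top of the small range seen so far, so a moderate move toward a lower number seems likelier than a further rise. The expected step is a 2.6-fold lower number from compound 2 to compound 3 (0.41 log units; beyond the scatter), and it is uncertain. For compound 3 the estimated value is 7000 nM, with an expected range of 1800 nM to 25000 nM.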

Compound 3, concentration for 50% growth inhibition: 10000 nM
Compound 3: the middle estimate sits 1.4-fold (0.15 log units) below what was measured, and the stated range covers the measured number.
By their numbers in this assay, from the lowest: compound 1; then compounds 3 and 2 (each within the scatter of the next).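

In this assay the move of the furan's attachment point gives a 1.8-fold lower number from compound 2 to compound 3 (0.26 log units; within the scatter) and so does not separate the two furans, which means that at this position on the carbonyl carbon, furan-3-yl and furan-2-yl cannot be told apart. The thiophene comparison is different: replacing thiophen-2-yl with furan-3-yl gives a 9.1-fold higher number from compound 1 to compound 3 (0.96 log units; beyond the scatter) and so repeats the loss first seen with furan-2-yl, showing that this gap does not depend on which of these two ways the furan is attached. Nothing available here explains why thiophen-2-yl stands apart from both furans.

Going by these compounds, it remains open whether thiophen-3-yl would match thiophen-2-yl or fall closer to the furans. The compounds shown also do not tell how a phenyl ring or a pyrrol-2-yl ring would compare on the same carbonyl carbon.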